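The compounds below may be only part of what the source reports. "The series", "measured", "known", "first", "only" and "open" are said of these compounds alone.

Within the data shown here, compound 3 (`C=C1C(=O)[C@]23C[C@@]1(O)CC[C@H]2c1ccc(O)c(C)c1[C@@H]3Cn1cc(-c2ccc(F)cc2)nn1`) is the one compound of the three for which a functional assay on MCF7 cells (Homo sapiens) for cytotoxicity, read by MTT assay, with a stated time of 4 days (a lower number here means a stronger inhibitor, a higher number a weaker inhibitor), returns a number: compound 3 gives 1700 nM. The other two come back only as limits. Compound 1 (`C=C1C[C@]23C[C@@]1(O)CC[C@H]2c1ccc(OS(=O)(=O)c2ccc(C)cc2)c(C)c1[C@@H]3Cn1cc(-c2ccc(Br)cc2)nn1`) sits at the limit of > 20000 nM in this assay. Compound 2 (`C=C1C[C@]23C[C@@]1(O)CC[C@H]2c1cc(Br)c(O)c(C)c1[C@@H]3Cn1cc(-c2ccc(OC)cc2)nn1`) likewise reaches only the limit of > 20000 nM in this assay. So two of the three readings stand at the limit of > 20000 nM in this assay, at which 2 of the 3 values shown sit, and compound 3 alone is placed by a measured value.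

Compound 4 (`C=C1C(=O)[C@]23C[C@@]1(O)CC[C@H]2c1ccc(O)c(C)c1[C@@H]3Cn1cc(-c2ccc(C)cc2)nn1`) is not yet measured. It differs from compound 3 by methyl in place of fluoro on an aromatic carbon. Among the measured compounds shown here, no measured pair of compounds shows this change, so there is no step to lean on. The expectation is that the step from compound 3 to compound 4 in this assay stays within the usual scatter, with no clear direction, as a 1.2-fold higher number from compound 3 to compound 4 (0.07 log units; within the scatter). Compound 4 is therefore estimated at 2000 nM in this assay, in a range from 700 nM to 6000 nM.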

Compound 4, half-maximal inhibitory concentration: 370 nM
For compound 4 the middle estimate is 5.4-fold (0.73 log units) above the measured one, outside the stated range (below it).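

In this assay, replacing 4-fluorophenyl with 4-methylphenyl gives a 4.6-fold lower number from compound 3 to compound 4 (0.66 log units; beyond the scatter). This is the first single change in the series shown, and it reveals that the read-out responds to what sits on this aromatic carbon, even when one heavy atom replaces another. Compound 1 and compound 2 offer no such reading, as their results are limits rather than numbers: the limit of > 20000 nM in this assay, at which 2 of the 4 values shown sit.

On these data alone, what remains open is how far this position tolerates other groups, such as an amine, a carboxylic acid or a longer chain like propyl. A single pair also cannot show whether the same change would have a similar effect on the core of compound 1 or compound 2, nor why the number falls.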